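The compounds below may be only part of what the source reports. "The series", "measured", "known", "first", "only" and "open" are said of these compounds alone.

Measured compounds in an ADME assay on Huh-7 cells (Homo sapiens) for cytotoxicity, read by MTT assay, with a stated time of 48 h; on this read-out higher numbers stand for lower toxicity in this test and lower numbers for higher toxicity in this test:
- compound 1, `CN(C)CCCCOC(=O)Nc1ccc(Cn2nc(-c3cnn(C)c3)c3ccccc3c2=O)cc1`, gives 55900 nM
- compound 2, `CN(C)CCCCOC(=O)Nc1ccc(Cn2nc(-c3cccc(C#N)c3)c3ccccc3c2=O)cc1`, gives 17200 nM
- compound 3, `CN(C)CCCCOC(=O)Nc1ccc(Cn2nc(-c3cccc(C(F)(F)F)c3)c3ccccc3c2=O)cc1`, gives 11600 nM

Compound 3 stands at the lowest of the three numbers in this assay. The step from compound 1 to compound 2 was a 3.3-fold lower number from compound 1 to compound 2 (0.51 log units; beyond the scatter), and the step from compound 1 to compound 3 was a 4.8-fold lower number from compound 1 to compound 3 (0.68 log units; beyond the scatter); between compound 2 and compound 3 the step was a 1.5-fold lower number from compound 2 to compound 3 (0.17 log units; within the scatter). Compound 4, `COc1ccccc1-c1nn(Cc2ccc(NC(=O)OCCCCN(C)C)cc2)c(=O)c2ccccc12`, differs from compound 3 in one place: 2-methoxyphenyl in place of 3-(trifluoromethyl)phenyl on an aromatic carbon. Both earlier swaps of the same group moved the number modestly, so for compound 4 a modest rise in this assay is expected, a 1.9-fold higher number from compound 3 to compound 4 (0.28 log units; within the scatter). Compound 4 is estimated at 22000 nM, within a range from 9000 nM to 55000 nM.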

Compound 4, half-maximal cytotoxic concentration: 44800 nM
The estimate for compound 4 lay 2.0-fold (0.31 log units) below the measured number; the measured number falls inside the stated range.
By their numbers in this assay, from the lowest: compounds 3 and 2 (each within the scatter of the next); then compounds 4 and 1 (each within the scatter of the next).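

In this assay, a phenyl ring at this position does not by itself bring the lower numbers: 2-methoxyphenyl gives a 3.9-fold higher number from compound 3 to compound 4 (0.59 log units; beyond the scatter) and a 2.6-fold higher number from compound 2 to compound 4 (0.42 log units; beyond the scatter). Against 1-methyl-1H-pyrazol-4-yl, the change gives a 1.2-fold lower number from compound 1 to compound 4 (0.10 log units; within the scatter), so this phenyl ring and that pyrazole read alike here. Nothing measured here explains the difference between the phenyl groups.

The compounds shown leave open whether the group or its place on the phenyl ring drives the step. 3-Methoxyphenyl, 2-(trifluoromethyl)phenyl or an aminophenyl group could help to separate these.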